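Chloro for Amino on the Aniline of a Sulfonyl Core

The source may hold more compounds than are shown below. What is called first, only, known or untested is meant among the compounds shown, and "the series" means these compounds.

Compound 3 `COc1ccc(S(=O)(=O)c2nc3ccccc3nc2Nc2cccc(N)c2)cc1` sits second highest of the three numbers measured in a functional assay on PC-3 cells (Homo sapiens) for cytotoxicity, read by MTT assay, with a stated time of 72 h (a higher number here means a weaker inhibitor, a lower number a stronger inhibitor), where compound 3 gives 8600 nM. Its nearest neighbour is compound 1 `Cc1ccc(S(=O)(=O)c2nc3ccccc3nc2Nc2ccc(Cl)cc2)cc1`, which in this assay gives 9660 nM; its furthest is compound 2 `COc1ccc(S(=O)(=O)c2nc3ccccc3nc2Nc2ccccc2)cc1`, which gives 1260 nM. Going by the values given here, the one step that connects compound 2 to compound 3 is a 6.8-fold higher number from compound 2 to compound 3 (0.83 log units; beyond the scatter). Compound 4 `COc1ccc(S(=O)(=O)c2nc3ccccc3nc2Nc2ccc(Cl)cc2)cc1` differs from compound 3 by 4-chlorophenyl in place of 3-aminophenyl on a nitrogen on an aromatic ring. Among the compounds with values here, this step bears on the amino step, since removing the amino undoes the change that raised the number from compound 2 to compound 3, while the chloro that enters has no measured step of its own; compound 1 carries the same 4-chlorophenyl but a different group on the sulfonyl ring, so its value can only be noted. For compound 4 the expected step is therefore a 2.2-fold lower number from compound 3 to compound 4 (0.33 log units; beyond the scatter), a lower number. Compound 4 is estimated at 4000 nM, with a range from 1200 nM to 12000 nM.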

Compound 4, half-maximal inhibitory concentration: 31800 nM
For compound 4 the middle estimate is 8.0-fold (0.90 log units) below the measured one, outside the stated range (above it).
By their numbers in this assay, from the lowest: compound 2; then compounds 3 and 1 (each within the scatter of the next); then compound 4.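

In this assay the aniline ring proves less forgiving than the amino step alone suggested: removing the amino does not bring the number back toward compound 2, as 4-chlorophenyl in place of 3-aminophenyl gives (a 3.7-fold higher number from compound 3 to compound 4 (0.57 log units; beyond the scatter)), and chloro in place of hydrogen gives (a 25-fold higher number from compound 2 to compound 4 (1.40 log units; beyond the scatter)), so both substituted rings here carry higher numbers than the unsubstituted phenyl. With 4-chlorophenyl held fixed, the sulfonyl ring also proves to matter, with methoxy in place of methyl giving (a 3.3-fold higher number from compound 1 to compound 4 (0.52 log units; beyond the scatter)). No measurement offered here explains either change.

The compounds shown leave open whether the higher number of compound 4 follows from the chloro itself or from where it sits on the ring. They also leave open how a carboxylic acid or a methyl group on that ring would read, and whether the methoxy step holds with the unsubstituted phenyl.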